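Aryl pyrazole chalcones: removing one methoxy from compound 2

The compounds below may be only part of what the source reports. "The series", "measured", "known", "first", "only" and "open" are said of these compounds alone.

Measured so far in a functional assay on T47D cells (Homo sapiens) for inhibition, read by sulforhodamine B assay, with a stated time of 48 h; on this read-out higher numbers stand for lower toxicity in this test and lower numbers for higher toxicity in this test:
compound 1 `COc1ccc(-c2cc(/C=C/C(=O)c3ccc(N)cc3)[nH]n2)cc1` gives 85800 nM
compound 2 `COc1cc(-c2cc(/C=C/C(=O)c3ccc(N)cc3)[nH]n2)cc(OC)c1OC` gives a limit, > 100000 nM
compound 3 `COc1cc(-c2cc(/C=C/C(=O)c3ccc(F)c(F)c3)[nH]n2)cc(OC)c1OC` gives a limit, > 100000 nM

Compound 2 does not stand at a number on this read-out; its value is the limit of the assay. The same holds for compound 3, whose value is also a limit. Only compound 1 gives a number, and it lies close to that limit. Among the compounds with values here, the one single-site step that is recorded, a step that the two limits leave unreadable from compound 2 to compound 3, runs between two limits and its size cannot be read, a consequence of the limit of > 100000 nM in this assay, at which 2 of the 3 values shown sit.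

Compound 4 `COc1ccc(-c2cc(/C=C/C(=O)c3ccc(N)cc3)[nH]n2)cc1OC` differs from compound 2 by hydrogen in place of methoxy on an aromatic carbon. Within the data shown here, no measured step covers this change; compound 1 and compound 2 differ in more than one place, so they show only that one methoxy pattern gives a number and the other a limit. Given this, compound 4 is expected to land near the top of the measured range, with a step of an at least 1.0-fold lower number from compound 2 to compound 4 (0.02 log units; that floor lies within the scatter) that is expected to be unreadable or within scatter. Compound 4 is therefore estimated at 95000 nM in this assay, between 60000 nM and 150000 nM, with a fair chance that only a limit is reported.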

Compound 4, concentration lethal to 50% of the cells: > 100000 nM
Compound 4: only a limit was reported; the forecaster's own chance of this, stated with the estimate: 55%; at least 1.0-fold (0.02 log units) between middle value and limit.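

In this assay compound 4 gives > 100000 nM, which is a limit of the assay. Within the data shown here, this yields the first readable single-site step for this methoxy position, an at least 1.1-fold higher number from compound 1 to compound 4 (0.06 log units; that floor lies within the scatter), for methoxy in place of hydrogen on an aromatic carbon; only a floor is fixed, so the data do not establish a real difference between the two compounds. The step from compound 2 to compound 4, hydrogen in place of methoxy, cannot be read because both ends sit at a limit: the limit of > 100000 nM in this assay, at which 3 of the 4 values shown sit.

The compounds shown leave open how far compound 2 and compound 4 actually lie beyond the limit, and so whether the methoxy groups on this ring change the read-out at all. They also leave open whether a hydroxy group, a chlorine atom or an amine in place of methoxy at this position would bring the series to a number rather than a limit.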